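Replacing methylsulfanyl with iodo in compound 2

The source may report more compounds than this note shows. Statements on the series, on what has been measured and on what is new or still open speak of the compounds shown alone.

Measured in an ADME assay on L6 cells (Rattus norvegicus) for inhibition, read by resazurin assay, with a stated time of 72 h; on this read-out lower numbers stand for stronger inhibition and higher numbers for weaker inhibition:
compound 1 `CSC[C@H]1O[C@@H](n2cnc3c(N)nc(F)nc32)[C@H](OC(C)=O)[C@@H]1OC(C)=O`: 15000 nM
compound 2 `CSC[C@H]1O[C@@H](n2cnc3c(N)nc(Cl)nc32)[C@H](OC(C)=O)[C@@H]1OC(C)=O`: 216000 nM
compound 3 `CS(=O)(=O)C[C@H]1O[C@@H](n2cnc3c(N)nc(Cl)nc32)[C@H](O)[C@@H]1O`: 156000 nM

Compound 2, at 216000 nM, lies within the scatter of compound 3, at 156000 nM, and well apart from compound 1. Compound 4 `CC(=O)O[C@@H]1[C@H](OC(C)=O)[C@@H](CI)O[C@H]1n1cnc2c(N)nc(Cl)nc21` keeps the chloro of compound 2 and changes one group: iodo in place of methylsulfanyl on a saturated chain carbon bound to a saturated ring carbon. Among the measured compounds shown here, no measured step touches that place. For the measured compounds named here, the only step available, a 14-fold higher number from compound 1 to compound 2 (1.16 log units; beyond the scatter), concerns an aromatic carbon, and it shows merely that a single swap can move this assay widely. A moderate move towards a lower number is expected, with wide uncertainty, namely a 3.6-fold lower number from compound 2 to compound 4 (0.56 log units; beyond the scatter). For compound 4 the estimated value is 60000 nM, with an expected range of 10000 nM to 220000 nM.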

Compound 4, half-maximal inhibitory concentration: 86000 nM
Beside the measured number, compound 4's estimate is 1.4-fold (0.16 log units) below it; low and high end bracket the measured number.
By their numbers in this assay, from the lowest: compound 1; then compounds 4, 3 and 2 (each within the scatter of the next, the first and the last beyond it).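

In this assay, the place on a saturated chain carbon bound to a saturated ring carbon now has a measured step of its own: iodo in place of methylsulfanyl gives a 2.5-fold lower number from compound 2 to compound 4 (0.40 log units; beyond the scatter). So this place responds to a single swap, though the step is modest, whereas the earlier step on an aromatic carbon was large. Nothing available here accounts for the change.

As far as these compounds go, whether an amine, a carboxylic acid or a longer chain at this place would move the number further remains open. Also open, from the compounds shown here alone, is whether the step would hold with fluoro in place of chloro on the aromatic carbon.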